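Neopentyl for tert-Butoxy in a Cytotoxicity Series

The source may report more compounds than this note shows. Statements on the series, on what has been measured and on what is new or still open speak of the compounds shown alone.

Two compounds have been examined so far, both in a functional assay on HL-60 cells (Homo sapiens) for cytotoxicity, read by MTT assay, with a stated time of 48 h (on this read-out higher numbers stand for weaker inhibition and lower numbers for stronger inhibition), as the shared test. Compound 1 (`CC[C@H](C)[C@H](NC(=O)C1CCN(C(=O)OC(C)(C)C)CC1)C(=O)N1Cc2cc(OCC(=O)NO)ccc2C[C@H]1C(=O)Nc1ccc(OC)cc1`) has no number, and its entry reads "not determined" (no result reported) in the record. Going by the values given here, compound 2 (`CC[C@H](C)[C@@H](CN1Cc2cc(OCC(=O)NO)ccc2C[C@H]1C(=O)Nc1ccc(OC)cc1)NC(=O)OC(C)(C)C`) gives 42700 nM as the only number available, so it cannot yet be ranked against any other compound. Among the compounds with values here, no pair of measured compounds shows how far a single change moves the read-out.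

Compound 3 (`CC[C@H](C)[C@@H](CN1Cc2cc(OCC(=O)NO)ccc2C[C@H]1C(=O)Nc1ccc(OC)cc1)NC(=O)CC(C)(C)C`) keeps the core of compound 2 and alters one group. Neopentyl stands in place of tert-butoxy on a carbonyl carbon, a change counted as neopentyl in place of tert-butoxy on a carbonyl carbon in the comparison of the two structures. Within the data shown here, with no measured step to draw on, the expectation starts from compound 2 at 42700 nM and assumes no shift beyond the usual scatter in this assay for this single exchange. The estimated 1.2-fold lower number from compound 2 to compound 3 (0.09 log units; within the scatter) is therefore expected to stay small, with either direction possible. Compound 3 is estimated at 35000 nM as its likely value (expected range 12000 nM to 90000 nM).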

Compound 3, half-maximal inhibitory concentration: 25700 nM
Beside the measured number, compound 3's estimate is 1.4-fold (0.13 log units) above it; measured number inside the range.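

In this assay, going by these compounds alone, the first measured step reads a 1.7-fold lower number from compound 2 to compound 3 (0.22 log units; within the scatter) for neopentyl in place of tert-butoxy on a carbonyl carbon whose other neighbour is an amide-type nitrogen. At this place, then, the same exchange can also be read as (tert-butoxycarbonyl)amino to (neopentylcarbonyl)amino, and an all-carbon group of the same heavy-atom count, without the hydrogen-bond acceptor counted on tert-butoxy, leaves the read-out within the usual scatter of this test, so that compound 2 and compound 3 cannot be told apart on this single pair. No further measurement is available that bears on this result, and what lies behind it stays unexplained.

On these data alone, what remains open is whether any other group on this carbonyl carbon, such as an amine, a carboxylic acid or a longer alkyl chain, would move the number beyond the scatter. With compound 1 still lacking a number and only one step in hand, the compounds shown also do not tell whether this exchange would behave the same way on a different part of the shared core.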